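Swapping Methoxy for Dimethylamino on the Benzyl Ring

This account rests on a few compounds, and the source may have more. Where it says the series, first, only, none or still open, it means among the compounds named here.

Measured so far in an assay on isolated protein for inhibition of Amine oxidase [flavin-containing] A (Homo sapiens), read by fluorescence, with a stated time of 30 min; on this read-out higher numbers stand for weaker inhibition and lower numbers for stronger inhibition:
Compound 1 `CCN(CCCCn1sc2cc(OC)c(OC)cc2c1=O)Cc1ccccc1`: 19900 nM
Compound 2 `CCN(CCCCn1sc2cc(OC)c(OC)cc2c1=O)Cc1ccccc1OC`: 9600 nM

Compound 2 stands lowest of the two numbers measured; its nearest neighbour is compound 1, from which it is separated by a 2.1-fold lower number from compound 1 to compound 2 (0.32 log units; beyond the scatter). That step is the only one measured, and it shows what a methoxy group adds when it replaces hydrogen on the benzyl ring.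

Compound 3 `CCN(CCCCn1sc2cc(OC)c(OC)cc2c1=O)Cc1ccccc1N(C)C` has not yet been measured. It differs from compound 2 by dimethylamino in place of methoxy on an aromatic carbon. Among the measured compounds shown here, no measured step covers the exchange of one of these groups for the other, so the single step available says only that a group at this place can matter, not which way this exchange will go.

With that in mind, compound 3 is expected to land near compound 2, the step of a 1.1-fold lower number from compound 2 to compound 3 (0.03 log units; within the scatter) lying within the scatter. Compound 3 is therefore estimated at 9000 nM in this assay, with a range from 3000 nM to 27000 nM.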

Compound 3, half-maximal inhibitory concentration: 9900 nM
Compound 3: the middle estimate sits 1.1-fold (0.04 log units) below what was measured, within the range that was stated.
By their numbers in this assay, from the lowest: compounds 2, 3 and 1 (each within the scatter of the next, the first and the last beyond it).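

In this assay, exchanging methoxy for dimethylamino at this place gives a 1.0-fold higher number from compound 2 to compound 3 (0.01 log units; within the scatter), so the two groups cannot be told apart here, even though they differ in their atoms. Set against hydrogen, dimethylamino gives a 2.0-fold lower number from compound 1 to compound 3 (0.30 log units; within the scatter), while methoxy gives a 2.1-fold lower number from compound 1 to compound 2 (0.32 log units; beyond the scatter); only the methoxy step lies beyond the scatter, but both are small, and this split is no firm sign that the two groups differ. Nothing available accounts for why the two groups read alike.

Going by these compounds, it remains open whether a chlorine, a hydroxyl or a carboxylic acid at this place would read like methoxy and dimethylamino. On these data alone, it also remains open whether any group here could bring the number far below those of compound 2 and compound 3.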